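The compounds below may be only part of what the source reports. "The series", "measured", "known", "first", "only" and "open" are said of these compounds alone.

Of the compounds shown here, three that share one core have been tested in a functional assay on MCF7 cells (Homo sapiens) for antiproliferative activity, read by MTT assay, with a stated time of 48 h; a higher number here means a weaker inhibitor, a lower number a stronger inhibitor. Compound 1 `O=C(NS(=O)(=O)c1ccccc1)c1cncc(Br)c1` gives 12900 nM. Compound 2 `Cc1ccc(S(=O)(=O)NC(=O)c2cncc(Br)c2)cc1` gives 9370 nM. Compound 3 `O=C(NS(=O)(=O)c1ccc(F)cc1)c1cncc(Br)c1` gives 980 nM, the lowest number of the three, and its gaps to both others lie beyond the scatter. Compound 4 `O=C(NS(=O)(=O)c1ccc(Cl)cc1)c1cncc(Br)c1` differs from compound 3 as follows: chloro in place of fluoro on an aromatic carbon. In words, this is chloro in place of fluoro on an aromatic carbon, para to a large group.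

For the measured compounds named here, three measured steps bear on this change. Fluoro in place of hydrogen gave a large step, a 13-fold lower number from compound 1 to compound 3 (1.12 log units; beyond the scatter). Methyl in place of hydrogen gave a 1.4-fold lower number from compound 1 to compound 2 (0.14 log units; within the scatter), which stays within the scatter. Fluoro in place of methyl gave a modest step, a 9.6-fold lower number from compound 2 to compound 3 (0.98 log units; beyond the scatter). Going by the values given here, no chloro compound has been measured, so these steps show only that the outcome depends on the group. Part of the advantage of compound 3 may be lost, and the expected step is a 2.2-fold higher number from compound 3 to compound 4 (0.35 log units; beyond the scatter), towards a higher number. In this assay, compound 4 is estimated at 2200 nM, within an expected range of 550 nM to 9000 nM.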

Compound 4, half-maximal inhibitory concentration: 70 nM
Beside the measured number, compound 4's estimate is 31-fold (1.50 log units) above it; measured number outside the range, below it.
By their numbers in this assay, from the lowest: compound 4; then compound 3; then compounds 2 and 1 (each within the scatter of the next).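

In this assay, the group on this aromatic carbon, para to a large group, proves even more decisive than the fluoro result suggested: chloro in place of fluoro gives a 14-fold lower number from compound 3 to compound 4 (1.15 log units; beyond the scatter), so exchanging one halogen for another can itself produce a large change. Chloro also stands well clear of the other two groups, with a 130-fold lower number from compound 2 to compound 4 (2.13 log units; beyond the scatter) against methyl and a 180-fold lower number from compound 1 to compound 4 (2.27 log units; beyond the scatter) against hydrogen, which makes compound 4 the strongest inhibitor of the four and shows that fluoro did not mark the best result at this place. Nothing available here explains why chloro gives the lower number.

Going by these compounds, whether bromo, trifluoromethyl or methoxy at the same place would go lower still remains open. On these data alone, it is also open whether chloro keeps its advantage when the bromo on the shared core is replaced by another group, such as an amine.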